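Furan-2-yl in place of methylsulfonyl on the shared core

The source may report more compounds than this note shows. Statements on the series, on what has been measured and on what is new or still open speak of the compounds shown alone.

Measured so far in a functional assay on KB cells (Homo sapiens) for cytotoxicity; a higher number here means a weaker inhibitor, a lower number a stronger inhibitor:
- compound 1 `C=CCOc1ccc2c(c1)C(=O)C=CC2=O`: 10200 nM
- compound 2 `CCOc1ccc2c(c1)C(=O)C=CC2=O`: 21400 nM
- compound 3 `CS(=O)(=O)Oc1ccc2c(c1)C(=O)C=CC2=O`: 11600 nM

The value of compound 3 gives it no clear rank among these three, since both steps that reach it stay within the scatter: a 1.1-fold higher number from compound 1 to compound 3 (0.06 log units; within the scatter), and a 1.8-fold lower number from compound 2 to compound 3 (0.27 log units; within the scatter). The next compound, compound 4 `O=C1C=CC(=O)c2cc(Oc3ccco3)ccc21`, has furan-2-yl in place of methylsulfonyl on an oxygen on an aromatic ring.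

All three measured steps change the group on this same oxygen, so all of them bear on the new change. The largest is modest, a 2.1-fold higher number from compound 1 to compound 2 (0.32 log units; beyond the scatter), and the other two lie within the scatter. Allyl, ethyl and methylsulfonyl on that oxygen therefore give closely spaced values in this assay. Going by the values given here, none of the measured compounds carries a ring there, however, so the data offer no direct precedent for furan-2-yl and no basis for choosing a direction. The expected step is a 1.1-fold lower number from compound 3 to compound 4 (0.02 log units; within the scatter), which means no change beyond the scatter is anticipated. Compound 4 is estimated at 11000 nM, with an expected range from 4500 nM to 25000 nM.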

Compound 4, half-maximal inhibitory concentration: 15800 nM
Compound 4: the middle estimate sits 1.4-fold (0.16 log units) below what was measured, and the stated range covers the measured number.
By their numbers in this assay, from the lowest: compounds 1, 3, 4 and 2 (each within the scatter of the next, the first and the last beyond it).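

In this assay, furan-2-yl on this oxygen stays within the scatter of each of the three earlier groups: a 1.4-fold higher number from compound 3 to compound 4 (0.13 log units; within the scatter), a 1.4-fold lower number from compound 2 to compound 4 (0.13 log units; within the scatter), and a 1.5-fold higher number from compound 1 to compound 4 (0.19 log units; within the scatter). Going by these compounds alone, compound 4 thus adds what the earlier compounds could not show: a five-membered aromatic ring can stand on this oxygen without a step beyond the scatter from any of the allyl, ethyl or methylsulfonyl compounds, and the only step beyond it among the four remains a 2.1-fold higher number from compound 1 to compound 2 (0.32 log units; beyond the scatter). Nothing in the information available explains even this small spread of values, and no cause can be assigned to the change from methylsulfonyl to furan-2-yl.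

As far as these compounds go, it remains open whether this narrow spread would hold for a phenyl ring, an amine, a carboxylic acid or a longer chain on the same oxygen. The four compounds also differ only in the group on this oxygen, so they do not show how much a change elsewhere on the shared core would shift the values in this assay.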